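A few compounds are considered here, and "the series" means these few. Any claim that something is new, unique, unknown or untested is made for them only; others in the source may bear on it.

Measured in a functional assay on PC-3 cells (Homo sapiens) for antiproliferative activity, read by MTT assay, with a stated time of 24 h; a higher number here means a weaker inhibitor, a lower number a stronger inhibitor:
- compound 1 `CCn1c(C(=O)N[C@H](C)C(=O)OC)ccc1C(CC)(CC)c1ccc(OCS(=O)(=O)c2ccccc2)c(C)c1`: > 50000 nM, a limit of the assay
- compound 2 `CCn1c(C(=O)N[C@H](CO)C(C)C)ccc1C(CC)(CC)c1ccc(OCS(=O)(=O)c2ccccc2)c(C)c1`: 7300 nM
- compound 3 `CCn1c(C(=O)N[C@H](C)C(=O)O)ccc1C(CC)(CC)c1ccc(OCS(=O)(=O)c2ccccc2)c(C)c1`: 20100 nM

Compound 3 has the higher of the two actual numbers, and its closest gap is a 2.8-fold higher number from compound 2 to compound 3 (0.44 log units; beyond the scatter). Compound 1 gives only a limit: the limit of > 50000 nM in this assay, at which 1 of the 3 values shown sits.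

Compound 4 `CCn1c(C(=O)NCCC(=O)O)ccc1C(CC)(CC)c1ccc(OCS(=O)(=O)c2ccccc2)c(C)c1` is an isomer of compound 3: 2-carboxyethyl in place of 1-carboxyethyl on an amide-type nitrogen. This puts 2-carboxyethyl in place of 1-carboxyethyl on an amide-type nitrogen, with the same atoms joined differently and the defined stereocentre gone.

Within the data shown here, no measured step makes this exact change, so the evidence is indirect. At the same nitrogen, the full exchange of groups gave a 2.8-fold higher number from compound 2 to compound 3 (0.44 log units; beyond the scatter), and an at least 6.8-fold lower number from compound 1 to compound 2 (0.83 log units; beyond the scatter) is a further exchange there, bounded only by the limit. Among the measured compounds shown here, removing the methyl from the ester oxygen gave an at least 2.4-fold lower number from compound 1 to compound 3 (0.39 log units; beyond the scatter), which shows only that the acid of compound 3 sits within the measured range.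

A shift within the same atoms is therefore expected to be smaller than the exchange of groups in a 2.8-fold higher number from compound 2 to compound 3 (0.44 log units; beyond the scatter). In this assay the expected result is a 1.1-fold higher number from compound 3 to compound 4 (0.04 log units; within the scatter), an estimate with no firm direction. For compound 4 the estimate is 22000 nM, with an expected range of 9000 nM to 50000 nM.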

Compound 4, half-maximal inhibitory concentration: 14400 nM
For compound 4 the middle estimate is 1.5-fold (0.18 log units) above the measured one, within the range that was stated.
By their numbers in this assay, from the lowest: compounds 2, 4 and 3 (each within the scatter of the next, the first and the last beyond it). At a limit, above all of these: compound 1.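

In this assay, moving from 1-carboxyethyl to 2-carboxyethyl on the amide-type nitrogen, which also removes the defined stereocentre, gives a 1.4-fold lower number from compound 3 to compound 4 (0.14 log units; within the scatter), so neither the shift of the acid along the chain nor the loss of the stereocentre gives a readable difference here. The comparison with the 1-(hydroxymethyl)-2-methylpropyl group gives a 2.0-fold higher number from compound 2 to compound 4 (0.30 log units; within the scatter), so the separation from compound 2 that stood beyond the scatter for compound 3 does not hold for its isomer, and that earlier gap cannot be read as a firm difference between the hydroxyl-bearing group and the acids as a class. Against the 1-(methoxycarbonyl)ethyl group the result is an at least 3.4-fold lower number from compound 1 to compound 4 (0.54 log units; beyond the scatter), which is only a bound, compound 1 being given as a limit: the limit of > 50000 nM in this assay, at which 1 of the 4 values shown sits.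

The pair of acids leaves the shift of the chain and the loss of the stereocentre joined in one change, so the opposite configuration of 1-carboxyethyl would be needed to read the stereocentre alone. On these data alone, it also stays open how a 2-(methoxycarbonyl)ethyl group, a longer chain such as 3-carboxypropyl, or an amine in place of the carboxylic acid would read at this nitrogen.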